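Swapping a vinyl for a methylsulfanyl on an isothiocyanate chain

This account rests on a few compounds, and the source may have more. Where it says the series, first, only, none or still open, it means among the compounds named here.

Three short-chain isothiocyanates have been tested in an assay on TREx-HEK cells for activation of transient receptor potential cation channel subfamily A member 1 (Homo sapiens), read by calcium flux; a lower number here means that less compound is needed, a higher number that more compound is needed for the effect. Compound 1 `C=CCCN=C=S` gives 360 nM. Compound 2 `C=CCCCCN=C=S` gives 1040 nM, and compound 3 `C=CCCCCCN=C=S` gives 1050 nM. Compound 3 therefore stands at the high end of the three numbers: its value and that of compound 2 sit within the scatter of each other, while compound 1 is clearly lower. Among the compounds with values here, the one step that can be read directly, a 1.0-fold higher number from compound 2 to compound 3 (0.00 log units; within the scatter), shows that adding a carbon to the tail between the nitrogen and the vinyl left this assay unchanged.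

Compound 4 `CSCCCCCN=C=S` is the next step from compound 3. The change is methylsulfanyl in place of vinyl on a saturated chain carbon, five bonds along the chain from an amide-type nitrogen. Within the data shown here, no measured pair here exchanges a vinyl for a methylsulfanyl, so the expectation rests only on the observation that the tail beyond the fourth chain carbon has so far mattered little, as the step from compound 2 to compound 3 shows. On that basis compound 4 is expected to stay close to compound 3 in this assay, with the estimated step being a 1.3-fold lower number from compound 3 to compound 4 (0.12 log units; within the scatter). The estimate for compound 4 is 800 nM, with a range from 300 nM to 2500 nM.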

Compound 4, half-maximal effective concentration: 500 nM
Compound 4: middle estimate off by 1.6-fold (0.20 log units), on the high side; low and high end bracket the measured number.
By their numbers in this assay, from the lowest: compounds 1 and 4 (each within the scatter of the next); then compounds 2 and 3 (each within the scatter of the next).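

Exchanging the vinyl for a methylsulfanyl, on a saturated chain carbon, five bonds along the chain from an amide-type nitrogen, gives a 2.1-fold lower number from compound 3 to compound 4 (0.32 log units; beyond the scatter) in this assay. So the far end of the chain can affect this number, even though adding one carbon to the vinyl tail gave only a 1.0-fold higher number from compound 2 to compound 3 (0.00 log units; within the scatter), which is within the scatter. The comparison with the shorter vinyl compound agrees, with (methylsulfanyl)methyl in place of vinyl giving a 2.1-fold lower number from compound 2 to compound 4 (0.32 log units; beyond the scatter), and although both steps lie beyond the scatter, they are modest; no supporting measurement bears on the reason for this shift.

The exchange adds a sulfur atom and removes a double bond in a single move, so these two changes cannot be told apart here, and a plain saturated tail such as butyl or pentyl would be the natural comparison. As far as these compounds go, it also remains open whether a methoxy group in the same place would behave like methylsulfanyl, and whether a longer chain ending in methylsulfanyl would keep the lower number.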